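Chain Lengthened, Methyl Removed: Estimating Compound 4

The compounds below may be only part of what the source reports. "The series", "measured", "known", "first", "only" and "open" are said of these compounds alone.

Of the compounds shown here, three built on one shared core have been tested in an assay on isolated protein for inhibition of Amine oxidase [flavin-containing] B (Homo sapiens), read by fluorescence and spectrophotometry; a lower number here means a stronger inhibitor, a higher number a weaker inhibitor. Compound 1 `O=C(CCCCc1cn(Cc2ccc3oc(-c4ccccc4)cc(=O)c3c2)nn1)Nc1ccccc1` gives 15600 nM. Compound 2 `O=C(CCc1cn(Cc2ccc3oc(-c4ccc(Cl)cc4)cc(=O)c3c2)nn1)Nc1ccc(Cl)cc1` gives 32900 nM, and compound 3 `Cc1ccc(NC(=O)CCc2cn(Cc3ccc4oc(-c5ccc(Cl)cc5)cc(=O)c4c3)nn2)cc1` gives 32900 nM. Compound 3 and compound 2 stand level at the digits shown, together the highest numbers of the three, and compound 1 sits at a lower number, a gap that lies beyond the usual scatter.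

Going by the values given here, the only single change measured so far is no change at the digits printed from compound 2 to compound 3 (within the scatter), a methyl in place of a chloro on an aromatic carbon, and it leaves the number unchanged within the scatter. Compound 4 `O=C(CCCCc1cn(Cc2ccc3oc(-c4ccc(Cl)cc4)cc(=O)c3c2)nn1)Nc1ccccc1` arises from compound 3 through a larger change: 2-(phenylcarbamoyl)ethyl in place of (4-methylphenyl)carbamoyl on a saturated chain carbon, two bonds along the chain from an aromatic carbon. This pairs the carbamoyl chain of compound 1 with the chloro-bearing core of compound 2 and compound 3, so compound 4 differs from compound 1 only by that chloro. Because no change at the digits printed from compound 2 to compound 3 (within the scatter) showed a chloro and a methyl to be interchangeable within the scatter, compound 4 is expected to land close to compound 1, giving a step of a 1.9-fold lower number from compound 3 to compound 4 (0.29 log units; within the scatter) toward a stronger inhibitor. Compound 4 is therefore estimated at 17000 nM, with a likely range from 8000 nM to 38000 nM.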

Compound 4, half-maximal inhibitory concentration: 32900 nM
Beside the measured number, compound 4's estimate is 1.9-fold (0.29 log units) below it; the measured number falls inside the stated range.
By their numbers in this assay, from the lowest: compound 1; then compounds 2, 3 and 4 (each within the scatter of the next).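

In this assay, 2-(phenylcarbamoyl)ethyl in place of (4-methylphenyl)carbamoyl gives no change at the digits printed from compound 3 to compound 4 (within the scatter), and the same group in place of (4-chlorophenyl)carbamoyl gives no change at the digits printed from compound 2 to compound 4 (within the scatter), so on the chloro-bearing core these three side chains cannot be told apart in this assay. Going by these compounds alone, the one change confined to a single small group, chloro in place of hydrogen on an aromatic carbon, gives a 2.1-fold higher number from compound 1 to compound 4 (0.32 log units; beyond the scatter); this modest step toward a weaker inhibitor is the first measured effect of that chloro with the chain held fixed. No available measurement accounts for either result.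

From the compounds shown here alone, the share of chain length alone stays open: each step that alters the chain here also alters the substituent on the terminal phenyl ring. Also open, going by these compounds, is whether a fluoro or a methoxy in place of the chloro, or a carboxylic acid or an amine in place of the phenylcarbamoyl end of the chain, would move the number beyond the usual scatter.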